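Sulfonamide alkyl chain extension in a TRPV1 antagonist series

The source may report more compounds than this note shows. Statements on the series, on what has been measured and on what is new or still open speak of the compounds shown alone.

Measured so far in an assay on cells for antagonist activity at transient receptor potential cation channel subfamily V member 1 (Homo sapiens), read by FLIPR and calcium flux, with a stated time of 15 min; a lower number here means a stronger inhibitor, a higher number a weaker inhibitor:
compound 1 `COc1cc(C(C)C(=O)NCc2ccc(C(F)(F)F)nc2N2CCC(C)CC2)cc(F)c1NS(C)(=O)=O` gives 0.3 nM
compound 2 `COc1cc(C(C)C(=O)NCc2ccc(C(F)(F)F)nc2N2CCC(C)CC2)cc(OC)c1NS(C)(=O)=O` gives 1.6 nM
compound 3 `CCS(=O)(=O)Nc1ccc(C(C)C(=O)NCc2ccc(C(F)(F)F)nc2N2CCC(C)CC2)cc1F` gives 4.4 nM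

Compound 3 has the highest number of the three; the gap to compound 2 and the larger gap to compound 1 both exceed the scatter. Among the measured compounds shown here, the one single-point step in this set, a 5.3-fold higher number from compound 1 to compound 2 (0.73 log units; beyond the scatter), concerns a methoxy for fluoro exchange on the aromatic ring and says nothing about the sulfonamide chain.

Compound 4 `CC1CCN(c2nc(C(F)(F)F)ccc2CNC(=O)C(C)c2ccc(NS(=O)(=O)C(C)C)c(F)c2)CC1` differs from compound 3 by methyl in place of hydrogen on a saturated chain carbon bound to a saturated chain carbon and a sulfonyl sulfur. For the measured compounds named here, no measured pair tests this change, so no direction can be drawn from the data. A step within the scatter is expected, a 1.1-fold higher number from compound 3 to compound 4 (0.06 log units; within the scatter), and compound 4 is estimated at 5 nM, between 2 nM and 13 nM.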

Compound 4, inhibition constant: 8.7 nM
Estimate against measurement, compound 4: 1.7-fold (0.24 log units) below; the measured number falls inside the stated range.
By their numbers in this assay, from the lowest: compound 1; then compound 2; then compounds 3 and 4 (each within the scatter of the next).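

Ethylsulfonyl to isopropylsulfonyl is the first change read on the sulfonamide chain: in this assay the step is a 2.0-fold higher number from compound 3 to compound 4 (0.30 log units; within the scatter) and cannot be told from no change. Methyl in place of hydrogen on this saturated chain carbon is therefore accommodated in this pair, with no shift that the assay resolves. No supporting data explain this result.

Still open, on these data alone, is how a propyl chain or a cyclopropyl ring on the sulfonyl sulfur would read. Also open, as far as these compounds go, is whether isopropylsulfonyl behaves alike with the methoxy-bearing ring of compound 1.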